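From phenoxy to 4-methylphenoxy: one added methyl

The source may hold more compounds than are shown below. What is called first, only, known or untested is meant among the compounds shown, and "the series" means these compounds.

In a functional assay on HCT-116 cells (Homo sapiens) for antiproliferative activity, read by MTT assay, with a stated time of 48 h (a higher number here means a weaker inhibitor of growth, a lower number a stronger inhibitor of growth), compound 1 `Cc1ccc(-c2cnc(N(Cc3ccccc3)Cc3ccc(C(=O)NO)cc3)s2)cc1` gives 48800 nM, while compound 2 `Cc1ccc(-c2cnc(N(CCCCOc3ccccc3)Cc3ccc(C(=O)NO)cc3)s2)cc1` gives 680 nM, the lower of the two numbers and so the stronger growth inhibition. Compound 3 `Cc1ccc(OCCCCN(Cc2ccc(C(=O)NO)cc2)c2ncc(-c3ccc(C)cc3)s2)cc1` differs from compound 2 at one place, with methyl in place of hydrogen on an aromatic carbon, para to a large group, turning phenoxy into 4-methylphenoxy: methyl in place of hydrogen on an aromatic carbon. Going by the values given here, only one measured step bears on this, and only loosely. That step, a 72-fold lower number from compound 1 to compound 2 (1.86 log units; beyond the scatter), put 3-phenoxypropyl in place of phenyl, and it was large and beyond the scatter. Among the compounds with values here, it exchanged a much bigger piece, however, and no measured step tests a methyl at this place. No shift beyond the scatter is therefore expected, in either direction. The expected step is a 1.1-fold lower number from compound 2 to compound 3 (0.04 log units; within the scatter). The estimated value for compound 3 is 620 nM, with an expected range of 260 nM to 1500 nM.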

Compound 3, concentration for 50% growth inhibition: 580 nM
Compound 3: the middle estimate sits 1.1-fold (0.03 log units) above what was measured, and the stated range covers the measured number.
By their numbers in this assay, from the lowest: compounds 3 and 2 (each within the scatter of the next); then compound 1.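

In this assay, turning phenoxy into 4-methylphenoxy leaves the number within the scatter (a 1.2-fold lower number from compound 2 to compound 3 (0.07 log units; within the scatter)). Going by these compounds alone, this is the first direct test of this aromatic carbon, para to a large group, and it shows that a single added methyl there brings no shift that can be told from the scatter. The much larger difference from the compound without the phenoxy-bearing chain stays in place with the methyl present (an 84-fold lower number from compound 1 to compound 3 (1.92 log units; beyond the scatter)), and nothing available accounts for either step.

On these data alone, it remains open whether a larger or different group at this carbon, such as methoxy, chlorine, an amine or a carboxylic acid, would move the number beyond the scatter. As far as these compounds go, it is also open how a shorter or longer chain would read with 4-methylphenoxy at its end.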